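The compounds below may be only part of what the source reports. "The series", "measured", "known", "first", "only" and "open" are said of these compounds alone.

Measured so far in a functional assay on DU-145 cells (Homo sapiens) for cytotoxicity, in the presence of a further agent that is not named here; a lower number here means a stronger inhibitor, a higher number a weaker inhibitor:
Compound 1 `Clc1ccc(-c2cc(-c3ccsc3)nc(-c3ccccc3Cl)c2)o1`: compound 1 gives 19300 nM.
Compound 2 `Clc1ccc(-c2cc(-c3cccnc3)nc(-c3cccs3)c2)o1`: compound 2 gives 13000 nM.
Compound 3 `Clc1ccc(-c2cc(-c3ccco3)nc(-c3cccs3)c2)o1`: compound 3 gives 21800 nM.

Compound 3 has the highest number of the three, but its gap to compound 1 and its gap to compound 2 each stay within the scatter, so no ranking among the three compounds is supported. For the measured compounds named here, the one single-point step on record, a 1.7-fold higher number from compound 2 to compound 3 (0.22 log units; within the scatter), also stays within the scatter.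

Compound 4 `Clc1ccc(-c2cc(-c3cccs3)nc(-c3ccccc3Cl)c2)o1` is the next compound: 2-chlorophenyl in place of furan-2-yl on an aromatic carbon. Going by the values given here, no measured step covers this exchange, and the step of a 1.7-fold higher number from compound 2 to compound 3 (0.22 log units; within the scatter) concerns a different entering group, so it bears only loosely on the question. Compound 1 carries a 2-chlorophenyl group together with a thiophen-3-yl group rather than the thiophen-2-yl group of compound 3 and compound 4, and its value sits within the scatter of compound 3. Nothing in the three values therefore points to a change beyond the scatter in this assay. Compound 4 is expected at 19000 nM (range 8000 nM to 45000 nM), which corresponds to an expected step of a 1.1-fold lower number from compound 3 to compound 4 (0.06 log units; within the scatter).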

Compound 4, half-maximal inhibitory concentration: 16800 nM
For compound 4 the middle estimate is 1.1-fold (0.05 log units) above the measured one; the range from low to high includes it.
By their numbers in this assay, from the lowest: compounds 2, 4, 1 and 3 (each within the scatter of the next).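

In this assay, the place next to the ring nitrogen now has exchanges that can be read directly: 2-chlorophenyl in place of furan-2-yl gives a 1.3-fold lower number from compound 3 to compound 4 (0.11 log units; within the scatter), and 2-chlorophenyl in place of pyridin-3-yl gives a 1.3-fold higher number from compound 2 to compound 4 (0.11 log units; within the scatter). At this place, therefore, going from furan-2-yl with 5 heavy atoms and 1 hydrogen-bond acceptor to 2-chlorophenyl with 7 heavy atoms and 0 hydrogen-bond acceptors produces no change beyond the scatter, and the same holds for the exchange from pyridin-3-yl. The series also gains its first single-place comparison of the two thiophene attachments, thiophen-2-yl in place of thiophen-3-yl, which gives a 1.1-fold lower number from compound 1 to compound 4 (0.06 log units; within the scatter); no independent data bear on these results.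

All four compounds shown carry an aromatic ring at this place, so the response to an amine, a carboxylic acid or a longer chain there remains open. The 5-chlorofuran-2-yl group is common to all four, so what it contributes to the values also cannot be read from them.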